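Adding a methyl to the three-membered ring of compound 3

A few compounds are considered here, and "the series" means these few. Any claim that something is new, unique, unknown or untested is made for them only; others in the source may bear on it.

Measured so far:
- compound 1, `Cn1c(CC2(c3ccccc3)CO2)cc(=O)n(C)c1=O`: 3700 nM
- compound 2, `CCCOc1nc(CC23CCCCC2O3)cc(=O)n1C`: > 352000 nM
- compound 3, `Cn1c(CC2(C)CO2)cc(=O)n(C)c1=O`: 4000 nM

In a functional assay for inhibition, with Mus musculus as the target (on this read-out lower numbers stand for higher toxicity in this test and higher numbers for lower toxicity in this test), compound 3 gives the highest of the two numbers, but its nearest neighbour, compound 1, sits within the scatter of it. For compound 2 the assay gave only a limit, (the limit of > 352000 nM in this assay, at which 1 of the 3 values shown sits), not a number.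

The new compound 4, `C[C@H]1O[C@@]1(C)Cc1cc(=O)n(C)c(=O)n1C`, differs from compound 3 in one place: 2,3-dimethyloxiran-2-yl in place of 2-methyloxiran-2-yl on a saturated chain carbon bound to an aromatic carbon. Among the measured compounds shown here, only one measured step bears on this. It also altered a group on the same three-membered ring: a 1.1-fold higher number from compound 1 to compound 3 (0.03 log units; within the scatter). That exchange of a methyl for a phenyl on a saturated ring carbon left the number unchanged beyond the scatter, so an added methyl on the 2,3-dimethyloxiran-2-yl group is expected to do little as well.

The expectation is therefore a step of no change at the digits printed from compound 3 to compound 4 (within the scatter), within the scatter. Compound 4 is estimated at 4000 nM, with a likely range from 1500 nM to 11000 nM.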

Compound 4, half-maximal cytotoxic concentration: 89000 nM
Compound 4: the middle estimate sits 22-fold (1.35 log units) below what was measured, outside the stated range (above it).
By their numbers in this assay, from the lowest: compounds 1 and 3 (each within the scatter of the next); then compound 4. At a limit, above all of these: compound 2.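

On the three-membered ring, a small added group can matter a great deal in this assay: 2,3-dimethyloxiran-2-yl in place of 2-methyloxiran-2-yl gives a large change (a 22-fold higher number from compound 3 to compound 4 (1.35 log units; beyond the scatter)), which on this read-out means lower toxicity in this test. The earlier exchange of phenyl for methyl gave no change beyond the scatter (a 1.1-fold higher number from compound 1 to compound 3 (0.03 log units; within the scatter)), so that step did not show how much this ring can respond to a change in its groups. The new group also carries 2 defined stereocentres, so this single step combines the added methyl with a defined spatial arrangement and cannot separate the two.

No measurement shown accounts for the size of this step. Going by these compounds, it remains open whether another stereoisomer of 2,3-dimethyloxiran-2-yl, or an ethyl group in place of the added methyl, would give a similar number.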